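Shortening the urea-hydrazide linker in the quinoline series

The compounds below may be only part of what the source reports. "The series", "measured", "known", "first", "only" and "open" are said of these compounds alone.

Compound 3 `COc1cc(NC(C)CCCNC(=O)NNC(=O)Nc2cccc(Cl)c2)c2ncccc2c1` gives 25000 nM in a functional assay on SW-620 cells (Homo sapiens) for inhibition, read by MTT assay, with a stated time of 72 h; a lower number here means a stronger inhibitor, a higher number a weaker inhibitor; compound 1 `COc1cc(NC(C)CCCNC(=O)NNC(=O)Nc2cc(C(F)(F)F)cc(C(F)(F)F)c2)c2ncccc2c1` gives 16000 nM and compound 2 `COc1cc(NC(C)CCCNC(=O)NNC(=O)Nc2cccc(C(F)(F)F)c2)c2ncccc2c1` gives 21000 nM, so all three numbers sit together within the usual scatter. Compound 4 `COc1cc(NC(C)CCCNC(=O)Nc2ccc(Cl)cc2)c2ncccc2c1` differs from compound 3 by 4-chlorophenyl in place of ((3-chlorophenyl)carbamoyl)amino on an amide-type nitrogen. Within the data shown here, the measured steps, a 1.3-fold higher number from compound 1 to compound 2 (0.12 log units; within the scatter) and a 1.2-fold higher number from compound 2 to compound 3 (0.08 log units; within the scatter), only exchange substituents on the aromatic ring and say nothing about the linker, which no pair here varies. Among the measured compounds shown here, with no step bearing on this change, the expectation for compound 4 is a step of a 1.3-fold lower number from compound 3 to compound 4 (0.10 log units; within the scatter), that is, no change beyond the scatter, though with wide uncertainty. Compound 4 is therefore estimated at 20000 nM, within 5000 nM to 80000 nM.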

Compound 4, half-maximal inhibitory concentration: 28000 nM
Compound 4: middle estimate off by 1.4-fold (0.15 log units), on the low side; the measured number falls inside the stated range.
By their numbers in this assay, from the lowest: compounds 1, 2, 3 and 4 (each within the scatter of the next).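

In this assay, among these compounds, the first change at the amide-type nitrogen gives a 1.1-fold higher number from compound 3 to compound 4 (0.05 log units; within the scatter) and so stays within the scatter, even though ((3-chlorophenyl)carbamoyl)amino leaves and 4-chlorophenyl enters. This single step also exchanges 3-chlorophenyl for 4-chlorophenyl, so the effects of the shorter linker and the ring change cannot be separated. No supporting measurement accounts for this result.

From the compounds shown here alone, it remains open whether an amine or a carboxylic acid on the phenyl ring, or a longer chain in the linker, would move the number beyond the scatter.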